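The source may hold more compounds than are shown below. What is called first, only, known or untested is meant among the compounds shown, and "the series" means these compounds.

Measured in a functional assay on A2780 cells (Homo sapiens) for antiproliferative activity, read by CellTiter-Glo, with a stated time of 72 h; a lower number here means a stronger inhibitor, a higher number a weaker inhibitor:
- Compound 1 `O=C(Nc1ccc(CN2Cc3ccccc3C2=O)cc1)N1CCC(c2cccnc2)CC1`: 1030 nM
- Compound 2 `C[C@H](NC(=O)c1ncccn1)c1ccc(NC(=O)N2CC(c3cccnc3)C2)cc1`: 36 nM
- Compound 3 `C[C@H](NC(=O)c1ncccn1)c1ccc(NC(=O)N2CC(c3ccc(N)nc3)C2)cc1`: 68 nM

Compound 3 lies within the scatter of compound 2, as a 1.9-fold higher number from compound 2 to compound 3 (0.28 log units; within the scatter) shows, and its number is well under that of compound 1. Compound 4 `CCC(=O)N[C@@H](C)c1ccc(NC(=O)N2CC(c3ccc(N)nc3)C2)cc1` carries one change from compound 3: ethyl in place of pyrimidin-2-yl on a carbonyl carbon. For the measured compounds named here, the single measured step, a 1.9-fold higher number from compound 2 to compound 3 (0.28 log units; within the scatter), concerns an amino group on an aromatic carbon, not this carbonyl carbon, so no measurement bears directly on the swap. With so little to go on, only a moderate rise in this assay is expected, and with wide uncertainty. The expected change is a 1.9-fold higher number from compound 3 to compound 4 (0.28 log units; within the scatter). For compound 4 the estimated value is 130 nM, with an expected range of 35 nM to 500 nM.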

Compound 4, half-maximal inhibitory concentration: 58 nM
Estimate against measurement, compound 4: 2.2-fold (0.35 log units) above, within the range that was stated.
By their numbers in this assay, from the lowest: compounds 2, 4 and 3 (each within the scatter of the next); then compound 1.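

Replacing pyrimidin-2-yl with ethyl on the carbonyl carbon gives a 1.2-fold lower number from compound 3 to compound 4 (0.07 log units; within the scatter) in this assay, so at this position the much smaller ethyl, with no ring, matches the aromatic ring within the scatter. Here, the ring and its hetero atoms are therefore not required for a value in this range. No measured evidence accounts for this result.

The compounds shown leave open how a longer chain, a cyclopropyl ring or a primary amine on this carbonyl carbon would read. They also leave open whether ethyl would fare the same without the amino group.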